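The source may hold more compounds than are shown below. What is called first, only, known or untested is meant among the compounds shown, and "the series" means these compounds.

Measured so far:
- compound 1, `O=S(=O)(NCC1CCN(CCCc2c[nH]c3ccc(-n4cnnc4)cc23)CC1)c1ccccc1`: 6.2 nM
- compound 2, `O[C@H]1Cc2ccccc2C1NC1CCN(CCCc2c[nH]c3ccc(-n4cnnc4)cc23)CC1`: 37 nM
- compound 3, `c1ccc2c(c1)CCC2NC1CCN(CCCc2c[nH]c3ccc(-n4cnnc4)cc23)CC1`: 8.9 nM

All three values come from an assay on CHO cells for displacement of a labelled ligand from 5-hydroxytryptamine receptor 1D (Homo sapiens); on this read-out lower numbers stand for stronger inhibition and higher numbers for weaker inhibition. Compound 3 sits second of the three numbers; one of its steps is a 1.4-fold higher number from compound 1 to compound 3 (0.16 log units; within the scatter), and the other is a 4.2-fold lower number from compound 2 to compound 3 (0.62 log units; beyond the scatter), so compound 3 and compound 1 are not separated by the scatter while compound 2 stands apart.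

Compound 4, `CN(C1CCN(CCCc2c[nH]c3ccc(-n4cnnc4)cc23)CC1)S(=O)(=O)c1ccccc1`, differs from compound 3 by methyl(phenylsulfonyl)amino in place of (2,3-dihydro-1H-inden-1-yl)amino on a saturated ring carbon. The group entering resembles the group on compound 1, though without the methylene spacer and with a methyl on the nitrogen. The step that bears most is a 1.4-fold higher number from compound 1 to compound 3 (0.16 log units; within the scatter), which shows the sulfonamide and the indanylamine groups give numbers within the scatter of each other. The hydroxy step a 4.2-fold lower number from compound 2 to compound 3 (0.62 log units; beyond the scatter) does not concern compound 4. Going by the values given here, no measured pair shows the effect of the methyl on the sulfonamide nitrogen or of removing the methylene spacer. The expected step is therefore a 1.1-fold higher number from compound 3 to compound 4 (0.05 log units; within the scatter), small and within the scatter of compound 3. Compound 4 is estimated at 10 nM, in the range 3 nM to 40 nM.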

Compound 4, half-maximal inhibitory concentration: 1.5 nM
The estimate for compound 4 lay 6.7-fold (0.82 log units) above the measured number; the whole stated range lies above it.
By their numbers in this assay, from the lowest: compound 4; then compounds 1 and 3 (each within the scatter of the next); then compound 2.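

In this assay, methyl(phenylsulfonyl)amino on the saturated ring carbon stands apart from both earlier groups, with a 4.1-fold lower number from compound 1 to compound 4 (0.62 log units; beyond the scatter) against ((phenylsulfonyl)amino)methyl and a 5.9-fold lower number from compound 3 to compound 4 (0.77 log units; beyond the scatter) against (2,3-dihydro-1H-inden-1-yl)amino. Compound 1 and compound 3 had left this position looking insensitive to the choice between their two groups, but the new group separates itself from both, and with a 25-fold lower number from compound 2 to compound 4 (1.39 log units; beyond the scatter) as the widest gap in the set, compound 4 is the strongest of the four. No measured evidence accounts for this gain.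

The step from compound 1 to compound 4 changes the methylene spacer and the methyl on the sulfonamide nitrogen together, so neither change can be read alone. The plain phenylsulfonylamino group would separate the two, and a benzoylamino group would test whether the sulfonyl itself matters.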